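From chloro to ethoxycarbonyl in a small series

The source may report more compounds than this note shows. Statements on the series, on what has been measured and on what is new or still open speak of the compounds shown alone.

In a functional assay on HeLa cells (Homo sapiens) for inhibition, read by CCK-8 assay, with a stated time of 48 h (on this read-out higher numbers stand for weaker inhibition and lower numbers for stronger inhibition), three compounds sharing one core have been measured. Compound 1 (`COc1cc(-c2ccnc3cc(-c4c[nH]c5ccccc45)nn23)cc(OC)c1OC`) gives 195 nM and carries 1H-indol-3-yl. Compound 2 (`COc1cc(-c2ccnc3cc(-c4ccc(Cl)cc4)nn23)cc(OC)c1OC`) gives 1490 nM and carries 4-chlorophenyl. Compound 3 (`COc1cc(-c2ccnc3cc(-c4cccc(C)c4)nn23)cc(OC)c1OC`) gives 4230 nM and carries 3-methylphenyl. Compound 2 thus holds the middle place, with the second highest of the three numbers.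

Compound 4 (`CCOC(=O)c1ccc(-c2cc3nccc(-c4cc(OC)c(OC)c(OC)c4)n3n2)cc1`) is still unmeasured. It differs from compound 2 by ethoxycarbonyl in place of chloro on an aromatic carbon, para to a large group (ethoxycarbonyl in place of chloro on an aromatic carbon). Within the data shown here, no measured step changes that group alone. The nearest evidence is a 2.8-fold higher number from compound 2 to compound 3 (0.45 log units; beyond the scatter) on exchanging 4-chlorophenyl for 3-methylphenyl, a modest step. Replacing 1H-indol-3-yl gave wider steps, with a 7.6-fold higher number from compound 1 to compound 2 (0.88 log units; beyond the scatter) and a 22-fold higher number from compound 1 to compound 3 (1.34 log units; beyond the scatter) in the same test, but compound 4 keeps a substituted phenyl, so the narrower step between the two phenyl compounds sets the scale. A small move toward weaker inhibition in this assay is therefore expected, estimated as a 2.0-fold higher number from compound 2 to compound 4 (0.30 log units; within the scatter) in size. Compound 4 is expected at 3000 nM with an estimated range from 1000 nM to 9000 nM in this measurement.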

Compound 4, half-maximal inhibitory concentration: > 10000 nM
Compound 4 was reported as a limit; the forecaster's own chance of this, stated with the estimate: 10%; at least 3.3-fold (0.52 log units) between middle value and limit.
By their numbers in this assay, from the lowest: compound 1; then compound 2; then compound 3. At a limit, above all of these: compound 4.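

In this assay compound 4 gives > 10000 nM as a limit of the assay and not as a number. This is the first change shown that alters only the group on an aromatic carbon para to a large group, and ethoxycarbonyl in place of chloro gives an at least 6.7-fold higher number from compound 2 to compound 4 (0.82 log units; beyond the scatter) with the rest of the structure held fixed, so this position does not accept the exchange without a clear move toward weaker inhibition. Of the compounds shown, only compound 4 stands at this limit: the limit of > 10000 nM in this assay, at which 1 of the 4 values shown sits.

On these data alone, how far the true number of compound 4 lies past the limit stays open, so the step has a lower bound but no measured size. It also remains open whether the carbonyl or the ethyl part of the ester accounts for the change, as the compounds shown include no carboxylic acid, no amide and no methoxycarbonyl group at this position to separate the two.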